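Phenyl Added to a Fused Core

The compounds below may be only part of what the source reports. "The series", "measured", "known", "first", "only" and "open" are said of these compounds alone.

Three compounds have been run in a functional assay on the whole organism for inhibition, with Rattus norvegicus as the target, with stated times of 1 h and 3.5 h, at a dose of 100 mg/kg by the oral route; a higher number here means more inhibition at the dose given (going by the name of the read-out), a lower number less inhibition. Compound 2 `CNc1nccc(C(C)(C)C)n1` gives 34% in this assay. Compound 1 `CNc1ncc(-c2ccccc2)c(C(C)(C)C)n1`, which carries the change (phenyl in place of hydrogen on an aromatic carbon), gives 37%; the step of a number 3 percentage points higher from compound 2 to compound 1 (within the scatter) is within the scatter, so the two values cannot be told apart. Compound 3 `CC(C)(C)C1CCc2nnc[n+]([O-])c2C1`, built on a different core, gives 36% in this assay; the difference between the two cores is not broken down here, and the values of compounds 3, 1 and 2 all lie within the scatter of one another.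

Compound 4 `CC(C)(C)C1CCc2nnc(-c3ccccc3)[n+]([O-])c2C1` is not yet measured. It is derived from compound 3 by the change (phenyl in place of hydrogen on an aromatic carbon). This is the same kind of change as that from compound 2 to compound 1, but the surroundings differ: in compound 1 the phenyl sits on a six-membered aromatic ring with 2 nitrogen, ortho to a tert-butyl group and para to a methylamino group, whereas in compound 4 it sits on a six-membered aromatic ring with 3 nitrogen that is part of a fused system of two rings, between two ring nitrogen atoms, ortho to a group of 1 heavy atom, meta and para to a fused ring.

For compound 4 a step of a number 2 percentage points higher from compound 3 to compound 4 (within the scatter) is expected in this assay, resting on the small step of a number 3 percentage points higher from compound 2 to compound 1 (within the scatter) seen for the same kind of change. Compound 4 is therefore estimated at 38%, with a likely range from 25% to 52%.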

Compound 4, a percentage reported as inhibition, in the whole organism at one dose (the size of the read-out at that dose, not a potency): 15%
Compound 4: middle estimate off by 23 percentage points, on the high side; measured number below the stated range.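

On the core of compound 3, phenyl in place of hydrogen on an aromatic carbon gives a step of a number 21 percentage points lower from compound 3 to compound 4 (beyond the scatter) in this assay. Among the compounds shown here, the same kind of change therefore cannot be carried from one core to the other with its size and direction intact, since the two cores give clearly different results: the same change on two cores in this assay, a number 3 percentage points higher (within the scatter) from compound 2 to compound 1 and a number 21 percentage points lower (beyond the scatter) from compound 3 to compound 4, 24 percentage points apart, beyond the scatter of two such steps This does not show which feature of the cores sets the two steps apart, because each core supplies only one pair, the cores differ in more than one place, and the phenyl has different surroundings on each, lying between two ring nitrogen atoms in compound 4; nor does it establish a rule for any core beyond these two.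

The compounds shown leave open whether the lower value of compound 4 belongs to phenyl itself or would also appear with another group at the same place on the core of compound 3, such as an amine or a carboxylic acid. They also leave open whether a substituted phenyl on that core would give a value nearer to that of compound 3 or to that of compound 4.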